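The source may hold more compounds than are shown below. What is called first, only, known or untested is meant among the compounds shown, and "the series" means these compounds.

Measured in a functional assay on U-87MG ATCC cells for cytotoxicity against U-87 MG (Homo sapiens), read by colorimetric assay and MTT assay; on this read-out lower numbers stand for stronger inhibition and higher numbers for weaker inhibition:
- Compound 1 (`COc1ccc2cc(-c3ccccc3)c(O)nc2c1`): 10000 nM
- Compound 2 (`COc1cc(OC)c2cc(-c3ccccc3)c(O)nc2c1`): 10000 nM
- Compound 3 (`COc1ccc(-c2cc3c(OC)cc(OC)cc3n(CC(=O)OCc3ccccc3)c2=O)cc1`): 10000 nM

On these numbers, compound 2 stands level with compound 1 and compound 3, so nothing separates the three. The next structure, compound 4 (`COc1cc(OC)c2cc(-c3ccc(O)cc3)c(O)nc2c1`), comes from compound 2 through one change: hydroxy in place of hydrogen on an aromatic carbon. This is hydroxy in place of hydrogen on an aromatic carbon, which turns phenyl to 4-hydroxyphenyl.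

For the measured compounds named here, only one measured step is of a comparable kind, a substitution on an aromatic carbon: no change at the digits printed from compound 1 to compound 2 (within the scatter). There, methoxy replaced hydrogen, and the read-out did not move. That step involves a different group at a different place, so it is weak evidence. Going by the values given here, no measured pair here shows what hydroxy does. Among the compounds with values here, with a single flat step as the only guide, no shift beyond the scatter is expected in this assay, in either direction. The expected step is no change at the digits printed from compound 2 to compound 4 (within the scatter). For compound 4 the estimate is 10000 nM, with an expected range of 4000 nM to 25000 nM.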

Compound 4, half-maximal inhibitory concentration: 10000 nM
Compound 4: the middle estimate sits on the measured number at the digits printed; low and high end bracket the measured number.
By their numbers in this assay, from the lowest: compounds 1, 2, 3 and 4 (each within the scatter of the next).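

Turning phenyl into 4-hydroxyphenyl gives no change at the digits printed from compound 2 to compound 4 (within the scatter) in this assay. For the compounds shown here, the only earlier step, no change at the digits printed from compound 1 to compound 2 (within the scatter), brought methoxy to a different place, so this result adds a second place on the molecule and a second kind of group, one that carries a hydrogen-bond donor, and the read-out stays flat for both. Nothing available here accounts for this lack of movement.

What the compounds shown leave open is whether any group on this aromatic carbon can shift the read-out, for instance an amine, a carboxylic acid or a longer chain such as butoxy. Also open, going by these compounds, is whether hydroxy on another carbon of the same ring would give a different number from compound 4.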